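The source may report more compounds than this note shows. Statements on the series, on what has been measured and on what is new or still open speak of the compounds shown alone.

Of the compounds shown here, two sharing the same core have been measured so far. Compound 1 `C#CCOc1ccc(/C=C/C(=O)c2ccc([N+](=O)[O-])cc2)cc1` and compound 2 `O=C(/C=C/c1ccc(OCc2cn(Cc3cccc(Br)c3)nn2)cc1)c1ccc(Br)cc1` were each tested in a functional assay on HepG2 cells (Homo sapiens) for inhibition, read by MTT assay, with a stated time of 48 h, tested at 10 uM; a lower number here means less inhibition of growth, a higher number more inhibition of growth at the concentration tested. In this assay compound 1 gives 27%. In this assay compound 2 gives 25%, the lowest of the two numbers, though its nearest neighbour, compound 1, lies only slightly higher and within the usual scatter, so the two values cannot be told apart. Compound 3 `O=C(/C=C/c1ccc(OCc2cn(Cc3ccc(F)cc3)nn2)cc1)c1ccc(Br)cc1` has not yet been measured. It differs from compound 2 in one place: 4-fluorophenyl in place of 3-bromophenyl on a saturated chain carbon bound to an aromatic nitrogen. This change sits on the saturated chain carbon bound to an aromatic nitrogen, away from the shared core. Going by the values given here, no measured pair shows such a step, so the expectation is no change beyond the scatter. Compound 3 is therefore expected to give 25%, between 12% and 40%. That estimate means a step from compound 2 to compound 3 of no change at the digits printed from compound 2 to compound 3 (within the scatter).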

Compound 3, percent growth inhibition at one concentration: 22%
For compound 3 the middle estimate is 3 percentage points above the measured one; low and high end bracket the measured number.
By their numbers in this assay, from the lowest: compounds 3, 2 and 1 (each within the scatter of the next).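

In this assay, going by these compounds alone, replacing 3-bromophenyl with 4-fluorophenyl gives a number 3 percentage points lower from compound 2 to compound 3 (within the scatter), the first step here in which only one place changes. This swap alters both the halogen and its place on the ring, and the two compounds cannot be told apart, so at this saturated chain carbon bound to an aromatic nitrogen these two groups are interchangeable in this read-out at the single concentration tested. No measurement shown here offers an explanation for this result.

The compounds shown leave open whether the two halogen changes would also show no difference if each were made alone. They also leave open whether an amine or a carboxylic acid on this ring, or a longer chain in place of the benzyl carbon, would give a step beyond the scatter.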